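Replacing the Bromophenyl Aniline with a Methoxyphenyl Aniline

The compounds below may be only part of what the source reports. "The series", "measured", "known", "first", "only" and "open" are said of these compounds alone.

Of the compounds shown here, three sharing one core have been measured in a functional assay on A549 cells (Homo sapiens) for antiproliferative activity, read by MTT assay, with a stated time of 72 h; on this read-out lower numbers stand for stronger inhibition and higher numbers for weaker inhibition. Compound 1 `COc1cc2ncnc(Nc3ccc(Cl)c(C(F)(F)F)c3)c2cc1OCCCCC(=O)Nc1ccc(S(N)(=O)=O)cc1` gives 9270 nM in this assay. Compound 2 `COc1cc2ncnc(Nc3cccc(Br)c3)c2cc1OCCCCC(=O)Nc1ccc(S(N)(=O)=O)cc1` gives 14900 nM in this assay. For compound 3 `COc1cc2ncnc(Nc3cc(F)c(F)c(F)c3)c2cc1OCCCCC(=O)Nc1ccc(S(N)(=O)=O)cc1` this assay returned only a limit, > 40000 nM (the limit of > 40000 nM in this assay, at which 1 of the 3 values shown sits). Among the numbers shown, compound 2 holds the higher of the two, though the step of a 1.6-fold higher number from compound 1 to compound 2 (0.21 log units; within the scatter) stays within the scatter, so the two cannot be ordered. The steps of an at least 4.3-fold higher number from compound 1 to compound 3 (0.63 log units; beyond the scatter) and an at least 2.6-fold higher number from compound 2 to compound 3 (0.42 log units; beyond the scatter) are beyond the scatter and show a real weakening.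

Compound 4 `COc1ccccc1Nc1ncnc2cc(OC)c(OCCCCC(=O)Nc3ccc(S(N)(=O)=O)cc3)cc12` is reached from compound 2 by the change (2-methoxyphenyl in place of 3-bromophenyl on a nitrogen on an aromatic ring). All three measured steps also exchange the aryl group on this nitrogen, so they bear on the new step, yet none of them introduces a 2-methoxyphenyl, and the measured aryl groups span only a narrow band. Given that exchanges of this group gave either no change in this assay or a loss, a step of a 1.5-fold higher number from compound 2 to compound 4 (0.17 log units; within the scatter) is expected, leaning toward a weaker number. Compound 4 is therefore estimated at 22000 nM in this assay, within a range from 8000 nM to 45000 nM.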

Compound 4, half-maximal inhibitory concentration: 24100 nM
Compound 4: middle estimate off by 1.1-fold (0.04 log units), on the low side; measured number inside the range.
By their numbers in this assay, from the lowest: compounds 1, 2 and 4 (each within the scatter of the next, the first and the last beyond it). At a limit, above all of these: compound 3.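

The step of a 1.6-fold higher number from compound 2 to compound 4 (0.21 log units; within the scatter) shows that, on this nitrogen on an aromatic ring, 2-methoxyphenyl cannot be told apart from 3-bromophenyl, so a group with no halogen, unlike those of compounds 1 to 3, still gives a number that can be read in this assay. The step of a 2.6-fold higher number from compound 1 to compound 4 (0.41 log units; beyond the scatter) is a modest weakening, which makes the 4-chloro-3-(trifluoromethyl)phenyl of compound 1 better than the 2-methoxyphenyl, although neither of the two can be separated from the 3-bromophenyl of compound 2. Compound 3 is held only as a limit, and the step of an at least 1.6-fold lower number from compound 3 to compound 4 (0.22 log units; that floor lies within the scatter) gives no more than a floor, which leaves compound 4 unordered against compound 3: the limit of > 40000 nM in this assay, at which 1 of the 4 values shown sits.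

The compounds shown leave open whether the oxygen of the methoxy group contributes anything, which a plain phenyl or a 2-methylphenyl on this nitrogen would address. They also leave open how a hydroxyl, an amine or a carboxylic acid on this aryl group would read, and whether a shorter or longer chain to the sulfonamide-bearing amide would shift all of these numbers together.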